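Moving the carboxamide around the azetidine ring

This account rests on a few compounds, and the source may have more. Where it says the series, first, only, none or still open, it means among the compounds named here.

Compound 1, `NC(=O)C1CCN1Cc1ccc(OCc2cccc(F)c2)cc1`: 46 nM
Compound 2, `C#CCN(C)C(=O)[C@H](C)NCc1ccc(OCc2cccc(F)c2)cc1`: > 10000 nM
Compound 3, `C#CCN(Cc1ccc(OCc2cccc(F)c2)cc1Cl)[C@@H](C)C(N)=O`: 68 nM

Of the compounds shown here, three carrying the shared core have been measured in an assay on Sf9 cells for inhibition of Amine oxidase [flavin-containing] B (Homo sapiens), with stated times of 15 min and 60 min; on this read-out higher numbers stand for weaker inhibition and lower numbers for stronger inhibition. Compound 1 gives 46 nM and compound 3 gives 68 nM; these two numbers lie within the usual scatter of each other, so no order between them can be claimed. The value of compound 2 is a limit of the assay and not a number, as compound 2 gives > 10000 nM (the limit of > 10000 nM in this assay, at which 1 of the 3 values shown sits). Compound 1 therefore sits among the two real numbers, with compound 3 close by and compound 2 at the limit.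

Compound 4, `NC(=O)C1CN(Cc2ccc(OCc3cccc(F)c3)cc2)C1`, has not yet been measured. It differs from compound 1 in one place: 3-carbamoylazetidin-1-yl in place of 2-carbamoylazetidin-1-yl on a saturated chain carbon bound to an aromatic carbon. Going by the values given here, no step between measured compounds bears on this particular change, so the expectation rests on the pattern that both compounds giving a number, compound 1 and compound 3, carry the carbamoyl group on the carbon next to the ring or chain nitrogen, while compound 2, whose carbamoyl-bearing arrangement is different, sits at the limit. The step of a 17-fold higher number from compound 1 to compound 4 (1.24 log units; beyond the scatter) is expected to run toward weaker inhibition, beyond the scatter. Compound 4 is estimated at 800 nM, with a range from 100 nM to 8000 nM.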

Compound 4, half-maximal inhibitory concentration: 1420 nM
Compound 4: the middle estimate sits 1.8-fold (0.25 log units) below what was measured; the range from low to high includes it.
By their numbers in this assay, from the lowest: compounds 1 and 3 (each within the scatter of the next); then compound 4. At a limit, above all of these: compound 2.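

In this assay, going by these compounds alone, putting 3-carbamoylazetidin-1-yl in place of 2-carbamoylazetidin-1-yl on a saturated chain carbon bound to an aromatic carbon gives a 31-fold higher number from compound 1 to compound 4 (1.49 log units; beyond the scatter), the first step that can be read between compounds differing in one place. The two groups have the same atoms, joined differently, so this large step shows that inhibition here depends on the arrangement of the group and not only on its composition. Nothing in the data given accounts for the size of this step.

Going by these compounds, it stays open how the 2-carbamoylazetidin-1-yl position would respond if a carboxylic acid or an amine took the place of the carbamoyl group. Also open, on these data alone, is whether the two mirror-image forms of compound 1 would give the same number.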